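Methoxy for fluoro on the benzoyl ring of compound 1

The source may report more compounds than this note shows. Statements on the series, on what has been measured and on what is new or still open speak of the compounds shown alone.

Two members of this series have numbers in a functional assay on CNE-2 cells (Homo sapiens) for cytotoxicity, read by MTT assay, with a stated time of 72 h; on this read-out lower numbers stand for stronger inhibition and higher numbers for weaker inhibition. Compound 1 `O=C(NC(=S)NNc1ncnc2ccccc12)c1ccccc1F` gives 4610 nM in this assay. Compound 2 `COc1cc2ncnc(NNC(=S)NC(=O)c3ccccc3OC)c2cc1OC`, which carries methoxy groups on the shared core as well as on the benzoyl ring, gives 8410 nM in this assay. Compound 1 holds the lower of the two numbers, but its gap to compound 2 lies within the scatter, so no order between them can be read.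

Compound 3 `COc1ccccc1C(=O)NC(=S)NNc1ncnc2ccccc12` has not been measured. It differs from compound 1 in one place: methoxy in place of fluoro on an aromatic carbon. Compound 3 thus carries the benzoyl substituent of compound 2 on the core of compound 1; compound 2 is not a direct step partner, since its core differs too.

Within the data shown here, no step between measured compounds sizes this change. What is known is that compound 2 gives 8410 nM and compound 1 gives 4610 nM, a gap within the scatter although the methoxy benzoyl group is present in one and absent in the other. The expected step is therefore a 1.3-fold higher number from compound 1 to compound 3 (0.11 log units; within the scatter), nothing beyond the scatter in either direction. For compound 3 the estimate in this assay is 6000 nM, with a range from 2500 nM to 14000 nM.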

Compound 3, half-maximal inhibitory concentration: 15700 nM
Compound 3: the middle estimate sits 2.6-fold (0.42 log units) below what was measured, outside the stated range (above it).
By their numbers in this assay, from the lowest: compounds 1, 2 and 3 (each within the scatter of the next, the first and the last beyond it).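

In this assay, going from 2-fluorophenyl to 2-methoxyphenyl on the shared core gives a 3.4-fold higher number from compound 1 to compound 3 (0.53 log units; beyond the scatter), the first direct size for this change in the series. The position on the aromatic carbon ortho to a large group is therefore not indifferent to what sits there: with the core held constant, methoxy gives weaker inhibition than fluoro, which the pair of compound 1 and compound 2 could not show, as those two differ in the core as well. The data at hand give no reason for this difference in the cell read-out, and nothing shown connects it to any measured property of the two groups.

The compounds shown leave open whether fluoro improves on an unsubstituted benzoyl ring or methoxy worsens it, and a bare hydrogen, a chlorine, a hydroxyl or an amine at this position would help to separate those two readings. They also leave open whether the same step holds on the dimethoxy-bearing core of compound 2, where only the methoxy benzoyl group is shown and the 2-fluorophenyl partner is absent.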